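Furanylmethyl amine variant of the piperidine series

This account rests on a few compounds, and the source may have more. Where it says the series, first, only, none or still open, it means among the compounds named here.

Compound 1 `O=S(=O)(NCC1CCN(CCCc2c[nH]c3ccc(-n4cnnc4)cc23)CC1)c1ccccc1` gives 60 nM in an assay on CHO cells for displacement of a labelled ligand from 5-hydroxytryptamine receptor 1B (Homo sapiens) (a higher number here means a weaker inhibitor, a lower number a stronger inhibitor), the highest of the three numbers recorded, though it sits within the scatter of both companions. Compound 2 `CN(Cc1ccsc1)C1CCN(CCCc2c[nH]c3ccc(-n4cnnc4)cc23)CC1` gives 35 nM and compound 3 `C[C@H](NCC1CCN(CCCc2c[nH]c3ccc(-n4cnnc4)cc23)CC1)c1ccccc1` gives 58 nM; the steps of a 1.7-fold lower number from compound 1 to compound 2 (0.23 log units; within the scatter), a 1.0-fold lower number from compound 1 to compound 3 (0.01 log units; within the scatter) and a 1.7-fold higher number from compound 2 to compound 3 (0.22 log units; within the scatter) all stay within the scatter. Compound 4 `CN(Cc1ccco1)C1CCN(CCCc2c[nH]c3ccc(-n4cnnc4)cc23)CC1` carries the change (((furan-2-yl)methyl)(methyl)amino in place of ((phenylsulfonyl)amino)methyl on a saturated ring carbon). The step of a 1.7-fold lower number from compound 1 to compound 2 (0.23 log units; within the scatter) is the closest guide, since compound 2 differs from compound 4 only in the five-membered aromatic ring. Going by the values given here, no step seen here leaves the scatter, so no movement beyond it is expected. Compound 4 is estimated at 40 nM, range 15 nM to 110 nM, corresponding to a 1.5-fold lower number from compound 1 to compound 4 (0.18 log units; within the scatter).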

Compound 4, half-maximal inhibitory concentration: 89 nM
Estimate against measurement, compound 4: 2.2-fold (0.35 log units) below; the measured number falls inside the stated range.
By their numbers in this assay, from the lowest: compounds 2, 3, 1 and 4 (each within the scatter of the next, the first and the last beyond it).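

Going by these compounds alone, on the saturated chain carbon bound to an amine nitrogen, furan-2-yl in place of thiophen-3-yl gives the first step beyond the scatter in this assay (a 2.5-fold higher number from compound 2 to compound 4 (0.41 log units; beyond the scatter)), a modest one. Compound 4 stays within the scatter of the two other side chains (a 1.5-fold higher number from compound 1 to compound 4 (0.17 log units; within the scatter); a 1.5-fold higher number from compound 3 to compound 4 (0.19 log units; within the scatter)), so this single ring exchange separates compounds that the wider side-chain exchanges do not. No available evidence accounts for this step.

The furan-2-yl and thiophen-3-yl names differ in both ring hetero atom and attachment point, and the compounds shown do not separate the two. Furan-3-yl and thiophen-2-yl on the same chain carbon remain the open comparisons.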